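The compounds below may be only part of what the source reports. "The series", "measured", "known", "first", "only" and "open" are said of these compounds alone.

Of the compounds shown here, three sharing one core have been measured in an in vitro functional assay on HEK285-7 cells for antagonist activity at prostaglandin D2 receptor 2 (Homo sapiens), read by BRET and beta-arrestin recruitment; a lower number here means a smaller maximal response, a higher number a larger maximal response. Compound 1 `COc1cc(-c2nc(C(c3ccc(F)cc3)c3ccc(F)cc3)sc2CC(=O)O)ccn1` gives 60%. Compound 2 `O=C(O)Cc1sc(Cc2ccccc2)nc1-c1ccc(Cl)cc1` gives 50%, and compound 3 `O=C(O)Cc1sc(COc2ccc(Cl)cc2)nc1-c1ccc(Cl)cc1` gives 50%. Of these three numbers, compound 1 carries the highest, yet its distance to compound 2 and to compound 3 both lie within the scatter, so no ranking among them can be drawn. Within the data shown here, the only step available, no change at the digits printed from compound 2 to compound 3 (within the scatter), shows that a 4-chlorophenoxy in place of phenyl on a saturated chain carbon bound to an aromatic carbon left the maximal response where it was.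

Compound 4 `O=C(O)Cc1sc(C(c2ccc(F)cc2)c2ccc(F)cc2)nc1-c1ccnc(Cl)c1` has not yet been measured. It differs from compound 1 by chloro in place of methoxy on an aromatic carbon. Among the measured compounds shown here, no measured step exchanges a methoxy for a chloro on an aromatic carbon, so the step from compound 2 to compound 3 bears on it only loosely, as the single example that one exchange of a group on the shared core can leave this assay unchanged. With nothing pointing in either direction, the step of no change at the digits printed from compound 1 to compound 4 (within the scatter) is expected to remain within the scatter. The estimate for compound 4 is 60%, within a range from 45% to 75%.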

Compound 4, largest response reached (reported as efficacy), in percent of the reference or control that the assay uses: 80%
Compound 4: middle estimate off by 20 percentage points, on the low side; the measured number lies above the stated range.
By their numbers in this assay, from the lowest: compounds 2, 3 and 1 (each within the scatter of the next); then compound 4.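

In this assay the change from 2-methoxypyridin-4-yl to 2-chloropyridin-4-yl gives a number 20 percentage points higher from compound 1 to compound 4 (beyond the scatter) and so marks this place, next to the ring nitrogen, as one where a single exchange moves the maximal response beyond the scatter, which the earlier step, no change at the digits printed from compound 2 to compound 3 (within the scatter), at another place on the shared core, did not show. The exchange is small: methoxy, with 2 heavy atoms and 1 hydrogen-bond acceptor, leaves, and chloro, with 1 heavy atom and 0 hydrogen-bond acceptors, enters. No measurement at hand connects the rise in maximal response to any property of either group.

The compounds shown leave open whether the higher response belongs to chloro itself or would also come with another group at this place, such as fluoro, methyl or an amine, or with plain hydrogen. They also leave open whether the same exchange would move the response in the same direction with a group other than the bis(4-fluorophenyl)methyl group that compound 1 and compound 4 share.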